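The source may report more compounds than this note shows. Statements on the series, on what has been measured and on what is new or still open speak of the compounds shown alone.

Compound 3 `C=CC(=O)Nc1cccc(-n2c(-c3nc(-c4cnn(C5CCN(C(C)=O)CC5)c4)cnc3N)nc3ccccc32)c1` is recorded in a physicochemical assay for solubility, at pH 7.4 (on this read-out higher numbers stand for higher solubility and lower numbers for lower solubility), only as a limit, < 10000 nM. Compound 1 `C=CC(=O)Nc1cccc(-n2c(-c3nc(-c4cnn(C5CCN(C)CC5)c4)cnc3N)nc3ccccc32)c1` likewise gives a limit in this assay, < 10000 nM. Compound 2 `C=CC(=O)Nc1cccc(-n2c(-c3nc(-c4cnn(C)c4)cnc3N)nc3ccccc32)c1` also gives a limit in this assay, < 10000 nM. Because all three values sit at the limit of < 10000 nM in this assay, at which 3 of the 3 values shown sit, the changes between them are a step that the two limits leave unreadable from compound 1 to compound 2, a step that the two limits leave unreadable from compound 1 to compound 3 and a step that the two limits leave unreadable from compound 2 to compound 3. Compound 4 `C=CC(=O)Nc1cccc(-n2c(-c3nc(-c4cnn(C5CCN(C(=O)CO)CC5)c4)cnc3N)nc3ccccc32)c1` differs from compound 3 by hydroxy in place of hydrogen on a saturated chain carbon bound to a carbonyl carbon. Within the data shown here, none of the measured steps therefore gives a readable size for this change, and no direction in this assay beyond the scatter can be taken from them. Compound 4 is estimated at 6000 nM, within 1500 nM to 20000 nM, which means an expected step that the limit leaves unreadable from compound 3 to compound 4, quite possibly reported again only as a limit.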

Compound 4, solubility: < 10000 nM
Compound 4 ended at the assay's limit; the forecaster's own chance of this, stated with the estimate: 60%; the middle value does not contradict the limit.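

In this assay compound 4 is recorded only as a limit, so its steps from compound 1, compound 2 and compound 3 cannot be read: the limit of < 10000 nM in this assay, at which 4 of the 4 values shown sit.

Going by these compounds, how these four compounds rank in this assay, and whether hydroxy in place of hydrogen shifts the read-out at all, remains open.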